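A few compounds are considered here, and "the series" means these few. Any claim that something is new, unique, unknown or untested is made for them only; others in the source may bear on it.

Compound 1 `COc1ccccc1-c1nnc(-c2ccc(C(=O)N/N=C/c3ccc([N+](=O)[O-])cc3)cc2)o1` has the higher of the two numbers measured in an ADME assay on THP-1 cells (Homo sapiens) for cytotoxicity (a lower number here means a stronger inhibitor, a higher number a weaker inhibitor), where compound 1 gives 203000 nM. Compound 2 `COc1ccccc1-c1nnc(-c2ccc(C(=O)N/N=C/c3ccc(Cl)cc3Cl)cc2)o1` gives 78800 nM in this assay, a modest step of a 2.6-fold lower number from compound 1 to compound 2 (0.41 log units; beyond the scatter) from a change of another group. Compound 3 `COc1ccccc1-c1nnc(-c2ccc(C(=O)N/N=C/c3ccc(O)cc3)cc2)o1` differs from compound 1 by hydroxy in place of nitro on an aromatic carbon. For the measured compounds named here, no measured step swaps nitro for hydroxy, so only that single modest step offers a loose guide. Compound 3 is therefore expected to stay close to the measured range, with a step of a 1.1-fold lower number from compound 1 to compound 3 (0.05 log units; within the scatter) inside the scatter, giving an estimated 180000 nM in this assay, between 70000 nM and 450000 nM.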

Compound 3, half-maximal inhibitory concentration: 261000 nM
Estimate against measurement, compound 3: 1.5-fold (0.16 log units) below, and the stated range covers the measured number.
By their numbers in this assay, from the lowest: compound 2; then compounds 1 and 3 (each within the scatter of the next).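

In this assay nitro and hydroxy cannot be told apart on this aromatic carbon, para to a large group: the swap gives a 1.3-fold higher number from compound 1 to compound 3 (0.11 log units; within the scatter) and no more. The 2,4-dichlorophenyl group of compound 2 therefore stands apart from both of these groups, now also with a 3.3-fold higher number from compound 2 to compound 3 (0.52 log units; beyond the scatter) on the hydroxy side. No measured evidence accounts for this result.

Still open, as far as these compounds go, is whether an amine or a carboxylic acid on this carbon would stay with compound 1 and compound 3 or come closer to compound 2. Also open, from the compounds shown here alone, is whether a single chlorine would be enough to come closer to compound 2.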